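1,3-Benzoxazol-2-yl in place of 1H-benzimidazol-2-yl on sulfur

The compounds below may be only part of what the source reports. "The series", "measured", "known", "first", "only" and "open" are said of these compounds alone.

In a functional assay on MGC-803 cells (Homo sapiens) for antiproliferative activity, read by MTT assay, with a stated time of 48 h (on this read-out higher numbers stand for weaker inhibition and lower numbers for stronger inhibition), compound 3 `COc1ccc(CN(C(=O)CSc2nc3ccccc3[nH]2)c2cc(OC)c(OC)c(OC)c2)cc1` gives 1230 nM, compound 1 `COc1ccc(CN(C(=O)CSc2nc3ccc(OC)cc3s2)c2cc(OC)c(OC)c(OC)c2)cc1` gives 1270 nM and compound 2 `COc1ccc(CN(C(=O)CCSc2nc3ccccc3o2)c2cc(OC)c(OC)c(OC)c2)cc1` gives 640 nM. For the measured compounds named here, compound 3 therefore lies within the scatter of both others, and the series so far shows no separation.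

The next structure is compound 4 `COc1ccc(CN(C(=O)CSc2nc3ccccc3o2)c2cc(OC)c(OC)c(OC)c2)cc1`, and the change is 1,3-benzoxazol-2-yl in place of 1H-benzimidazol-2-yl on a sulfur.

Going by the values given here, no measured step makes this exact swap. The nearest is a 1.0-fold lower number from compound 1 to compound 3 (0.01 log units; within the scatter), which also exchanges the group on a sulfur. Compound 2 already carries the entering group, as ((1,3-benzoxazol-2-yl)sulfanyl)methyl where compound 4 has (1,3-benzoxazol-2-yl)sulfanyl. The steps involving it are a 1.9-fold higher number from compound 2 to compound 3 (0.28 log units; within the scatter) and a 2.0-fold lower number from compound 1 to compound 2 (0.30 log units; within the scatter).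

With every measured step inside the scatter, no step beyond the scatter is expected. In this assay the expected step is a 1.4-fold lower number from compound 3 to compound 4 (0.14 log units; within the scatter), its slight direction resting only on the value of compound 2 at 640 nM.

Compound 4 is estimated at 900 nM, with an expected range from 400 nM to 2000 nM.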

Compound 4, half-maximal inhibitory concentration: 450 nM
Beside the measured number, compound 4's estimate is 2.0-fold (0.30 log units) above it, and the stated range covers the measured number.
By their numbers in this assay, from the lowest: compounds 4, 2, 3 and 1 (each within the scatter of the next, the first and the last beyond it).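

On a sulfur in this assay, 1,3-benzoxazol-2-yl in place of 1H-benzimidazol-2-yl gives a 2.7-fold lower number from compound 3 to compound 4 (0.44 log units; beyond the scatter) and the same group in place of 6-methoxy-1,3-benzothiazol-2-yl gives a 2.8-fold lower number from compound 1 to compound 4 (0.45 log units; beyond the scatter) and so, unlike every earlier step, these two separate compounds in the series. Chain length shows no such separation: (1,3-benzoxazol-2-yl)sulfanyl in place of ((1,3-benzoxazol-2-yl)sulfanyl)methyl gives a 1.4-fold lower number from compound 2 to compound 4 (0.15 log units; within the scatter) and leaves the two chain lengths unresolved. No supporting data are available to account for the gain seen with 1,3-benzoxazol-2-yl.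

Compound 1 differs from compound 4 in both the ring hetero atom and the methoxy group, so the compounds shown do not tell these two apart, and unsubstituted 1,3-benzothiazol-2-yl would address that question. Also open, as far as these compounds go, is how 1-methyl-1H-benzimidazol-2-yl, which carries a methyl group on the ring nitrogen, would compare on the same sulfur.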